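Swapping Chloro for Trifluoromethyl on the Cinnamamide Ring

The compounds below may be only part of what the source reports. "The series", "measured", "known", "first", "only" and "open" are said of these compounds alone.

Compound 2 `COc1cc(NC(C)CCCNC(=O)/C=C/c2ccc(Cl)cc2)c2ncccc2c1` is the only one of the two measured compounds with a firm number in an ADME assay on L6 cells (Rattus norvegicus) for cytotoxicity, read by resazurin assay, with a stated time of 70 h; a lower number here means a stronger inhibitor, a higher number a weaker inhibitor: compound 2 gives 7.1 ug/mL. Compound 1 `COc1cc(NC(C)CCCNC(=O)/C=C/c2ccc(OC)c(OC)c2)c2ncccc2c1` reaches only the limit of this assay, > 100 ug/mL, and that is a limit rather than a number (the limit of > 100 ug/mL in this assay, at which 1 of the 2 values shown sits). Among the measured compounds shown here, the single measured step, an at least 14-fold lower number from compound 1 to compound 2 (1.14 log units; beyond the scatter), shows that the group on the aromatic ring at the end of the chain can move the result a long way. Compound 3 `COc1cc(NC(C)CCCNC(=O)/C=C/c2ccc(C(F)(F)F)cc2)c2ncccc2c1` differs from compound 2 by trifluoromethyl in place of chloro on an aromatic carbon. For the measured compounds named here, no measured step covers this exact exchange; the one step that exists concerns a different ring group. The change from compound 2 to compound 3 is therefore expected to be modest, a 1.4-fold lower number from compound 2 to compound 3 (0.15 log units; within the scatter), within the scatter. Compound 3 is estimated at 5 ug/mL, most likely between 2 ug/mL and 15 ug/mL.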

Compound 3, half-maximal inhibitory concentration: 73.1 ug/mL
Beside the measured number, compound 3's estimate is 15-fold (1.16 log units) below it; measured number above the stated range.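

In this assay the exchange of chloro for trifluoromethyl is far from small: it gives a 10-fold higher number from compound 2 to compound 3 (1.01 log units; beyond the scatter) and shows that this one group, on an aromatic carbon para to a large group, can change the result by itself, even with the rest of the molecule unchanged. Against the 3,4-dimethoxyphenyl group, the 4-(trifluoromethyl)phenyl group gives an at least 1.3-fold lower number from compound 1 to compound 3 (0.13 log units; that floor lies within the scatter) and so sets only a floor, which does not show that the two groups differ. Compound 1 stands at a limit, not a number: the limit of > 100 ug/mL in this assay, at which 1 of the 3 values shown sits.

As far as these compounds go, whether a bromine, a nitrile or a methyl group in the same place would give a number closer to that of compound 2 or compound 3 remains open. So does whether the exchange of chloro for trifluoromethyl would have the same effect with a longer chain.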